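A Cyclopropyl Ketone on the Same Core

This account rests on a few compounds, and the source may have more. Where it says the series, first, only, none or still open, it means among the compounds named here.

Two compounds share one core here. Compound 1 `COC(=O)C1=C(C)NC(=O)NC1c1ccoc1` is the methyl ester, and in an assay on membranes from HeLa cells for displacement of a labelled ligand from adenosine receptor A3 (Homo sapiens), read by scintillation counting, with a stated time of 180 min, tested at 1 uM (a higher number here means more inhibition at the concentration tested (going by the name of the read-out), a lower number less inhibition), compound 1 gives 2%. Compound 2 `CC(=O)C1=C(C)NC(=O)NC1c1ccoc1` carries an acetyl group in place of that ester, and in this assay compound 2 gives 2%. Within the data shown here, the one step measured so far, no change at the digits printed from compound 1 to compound 2 (within the scatter), is the exchange of methoxy for methyl on the carbonyl carbon, and it left the read-out where it was. Compound 2 therefore stands level with compound 1, and both sit at a low level of inhibition at the single concentration tested.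

The next compound, compound 3 `CC1=C(C(=O)C2CC2)C(c2ccoc2)NC(=O)N1`, differs from compound 2 in one place: cyclopropyl in place of methyl on a carbonyl carbon. Among the measured compounds shown here, the only step that bears on this change is the one from compound 1 to compound 2 at the same carbonyl carbon, which was flat. On that basis, no step beyond the scatter is expected in this assay, and the estimated step of a number 2 percentage points higher from compound 2 to compound 3 (within the scatter) is small. Compound 3 is expected to give 4%, within a range from -8% to 18%.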

Compound 3, a percentage reported as inhibition, at one concentration (the size of the read-out at that concentration, not a potency): 16%
The estimate for compound 3 lay 12 percentage points below the measured number, and the stated range covers the measured number.
By their numbers in this assay, from the lowest: compounds 1 and 2 (each within the scatter of the next); then compound 3.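

The carbonyl carbon of the shared core had shown no response to the exchange of methoxy for methyl, but in this assay it proves sensitive to a larger change: cyclopropyl in place of methyl gives a number 14 percentage points higher from compound 2 to compound 3 (beyond the scatter) and cyclopropyl in place of methoxy gives a number 14 percentage points higher from compound 1 to compound 3 (beyond the scatter) at the same place. Among these compounds, compound 3 thus provides the first step at this position that lies beyond the scatter, and the two steps agree in direction and size, whichever of the two earlier compounds is taken as the starting point. No measurement shown here explains the gain, and nothing shown gives a reason for it.

The compounds shown do not separate the presence of the three-membered ring from the larger number of carbon atoms, a question that an open chain such as isopropyl or a larger ring such as cyclobutyl on the same carbonyl carbon would address. From the compounds shown here alone, it also remains open how an amine at this place would read, and whether the rise seen at one concentration would carry over to a measured potency.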